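The source may report more compounds than this note shows. Statements on the series, on what has been measured and on what is new or still open speak of the compounds shown alone.

Notes on the series. Three measured compounds share one core and differ only in the group on the carbonyl carbon of the amide. Compound 1 `CC1(C)Cc2c(sc(NC(=O)C3(O)CC3)c2C(N)=O)C(C)(C)O1` gives 23 nM in an assay on cells for positive allosteric modulation of Cystic fibrosis transmembrane conductance regulator variant F508del (Homo sapiens), with stated times of 10 min and 7 s, in the presence of a further agent that is not named here; on this read-out higher numbers stand for an effect only at larger amounts of compound and lower numbers for an effect already at smaller amounts. Compound 2 `CC1(C)Cc2c(sc(NC(=O)C3(CO)CC3)c2C(N)=O)C(C)(C)O1` gives 15 nM in this assay, and the step of a 1.5-fold lower number from compound 1 to compound 2 (0.19 log units; within the scatter) is within the scatter. Compound 3 `CC(C)(C)CC(O)C(=O)Nc1sc2c(c1C(N)=O)CC(C)(C)OC2(C)C` gives 0.54 nM in this assay and stands lowest of the three, with both steps into it beyond the scatter: a 43-fold lower number from compound 1 to compound 3 (1.63 log units; beyond the scatter) and a 28-fold lower number from compound 2 to compound 3 (1.44 log units; beyond the scatter).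

Compound 4 `Cc1cn[nH]c1C(=O)Nc1sc2c(c1C(N)=O)CC(C)(C)OC2(C)C` is not yet measured. The change from compound 3 to compound 4 is a group of 6 heavy atoms (4 carbon, 2 nitrogen; one five-membered aromatic ring with 2 hetero atoms) in place of a group of 7 heavy atoms (6 carbon, 1 oxygen; no ring), on a carbonyl carbon. Among the compounds with values here, the steps that bear on this are the two into compound 3, a 43-fold lower number from compound 1 to compound 3 (1.63 log units; beyond the scatter) and a 28-fold lower number from compound 2 to compound 3 (1.44 log units; beyond the scatter), in which the acyclic group took the place of a ring group on the carbonyl carbon and the number fell by a large amount each time. Compound 4 goes the other way, putting a ring group back on the carbonyl carbon, though an aromatic one unlike the three-membered rings of compounds 1 and 2. A rise beyond the scatter is therefore expected in this assay, of roughly the order of the steps into compound 3, with wide uncertainty since no aromatic group on the carbonyl carbon has been measured. Compound 4 is expected to give 10 nM, within a range of 2 nM to 50 nM. The step this estimate implies is a 19-fold higher number from compound 3 to compound 4 (1.27 log units; beyond the scatter).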

Compound 4, half-maximal effective concentration: 2 nM
For compound 4 the middle estimate is 5.0-fold (0.70 log units) above the measured one; the range from low to high includes it.
By their numbers in this assay, from the lowest: compound 3; then compound 4; then compounds 2 and 1 (each within the scatter of the next).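

Placing an aromatic ring on the carbonyl carbon gives lower numbers in this assay than either three-membered ring, with a 7.5-fold lower number from compound 2 to compound 4 (0.88 log units; beyond the scatter) and a 12-fold lower number from compound 1 to compound 4 (1.06 log units; beyond the scatter), so the presence of a ring group on this carbon does not by itself bring the higher numbers seen for compound 1 and compound 2. The acyclic group of compound 3 still gives the lowest number of the series, with a 3.7-fold higher number from compound 3 to compound 4 (0.57 log units; beyond the scatter), but this gap is smaller than the steps from either cyclopropyl compound to compound 3, and 4-methyl-1H-pyrazol-5-yl therefore recovers much of the difference between the acyclic and cyclopropyl groups. No measurement in hand accounts for these differences between the groups.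

The compounds shown cannot say how much the methyl on the 4-methyl-1H-pyrazol-5-yl group contributes to the number of compound 4, or how a plain 1H-pyrazol-5-yl or a phenyl ring would compare at this position. Also open, as far as these compounds go, is how the acyclic group of compound 3 would read with an amine in place of its hydroxy, or with a longer chain.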